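Notes on compound 3: carbamoyl restored on the ring nitrogen

The compounds below may be only part of what the source reports. "The series", "measured", "known", "first", "only" and "open" are said of these compounds alone.

Going by the values given here, compound 2 `COc1cc2nc(N3CCN(c4ccccc4)CC3)cc(N)c2cc1OC` gives 1.72 nM in an assay on brain for displacement of a labelled ligand from Adrenergic receptor alpha-1 (Rattus norvegicus) (a higher number here means a weaker inhibitor, a lower number a stronger inhibitor), the highest of the two numbers measured so far; compound 1 `CCCNC(=O)N1CCN(c2cc(N)c3cc(OC)c(OC)cc3n2)CC1` gives 0.44 nM. Compound 3 `COc1cc2nc(N3CCN(C(=O)Nc4ccccc4)CC3)cc(N)c2cc1OC` differs from compound 2 by phenylcarbamoyl in place of phenyl on an amine nitrogen in a ring. Among the compounds with values here, the one step that bears on this, a 3.9-fold higher number from compound 1 to compound 2 (0.59 log units; beyond the scatter), exchanged a propylcarbamoyl for a phenyl; compound 3 brings a carbamoyl back while keeping the phenyl, so a lower number in this assay is expected, of roughly the size of that step reversed. Compound 3 is therefore estimated at 0.6 nM, between 0.2 nM and 2 nM, an expected step of a 2.9-fold lower number from compound 2 to compound 3 (0.46 log units; beyond the scatter).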

Compound 3, inhibition constant: 0.34 nM
For compound 3 the middle estimate is 1.8-fold (0.25 log units) above the measured one; the measured number falls inside the stated range.
By their numbers in this assay, from the lowest: compounds 3 and 1 (each within the scatter of the next); then compound 2.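

The phenyl is tolerated on the amine nitrogen in a ring when a carbamoyl carries it, as adding that unit gives (a step of a 5.1-fold lower number from compound 2 to compound 3 (0.70 log units; beyond the scatter)) in this assay. With the carbamoyl in place, the group on the amide-type nitrogen can be propyl or phenyl with no change beyond the scatter (a step of a 1.3-fold lower number from compound 1 to compound 3 (0.11 log units; within the scatter)). No measurement available here accounts for either step.

Open, from the compounds shown here alone, is whether a longer chain or a benzyl group on the amide-type nitrogen fits the same reading. Also open, going by these compounds, is whether a plain acetyl could stand in for the carbamoyl.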